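This account rests on a few compounds, and the source may have more. Where it says the series, first, only, none or still open, it means among the compounds named here.

Of the compounds shown here, three built on one shared core have been tested in a functional assay on Huh-7 cells (Homo sapiens) for inhibition, read by sulforhodamine B assay, with a stated time of 72 h; on this read-out higher numbers stand for weaker inhibition and lower numbers for stronger inhibition. Compound 1 `C=CC(=O)Nc1cc(CCO)cc(C)c1Nc1ncc2cc(-c3c(Cl)c(OC)cc(OC)c3Cl)ccc2n1` gives 2410 nM in this assay, and compound 2 `C=CC(=O)Nc1cc(CCCN(C)C)cc(C)c1Nc1ncc2cc(-c3c(Cl)c(OC)cc(OC)c3Cl)ccc2n1` gives 2240 nM. The change from compound 1 to compound 2, (dimethylamino)methyl in place of hydroxy on a saturated chain carbon, two bonds along the chain from an aromatic carbon, produced a 1.1-fold lower number from compound 1 to compound 2 (0.03 log units; within the scatter). Compound 3 `C=CC(=O)Nc1cc(SC)ccc1Nc1ncc2cc(-c3c(Cl)c(OC)cc(OC)c3Cl)ccc2n1` gives 936 nM in this assay, the lowest of the three numbers, and its gaps to compound 2 and to compound 1 both lie beyond the scatter.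

Compound 4 `C=CC(=O)Nc1cc(S(C)(=O)=O)ccc1Nc1ncc2cc(-c3c(Cl)c(OC)cc(OC)c3Cl)ccc2n1` has not yet been measured. It differs from compound 3 by methylsulfonyl in place of methylsulfanyl on an aromatic carbon. Within the data shown here, no measured step bears on this exchange: the one measured step altered a group on a chain elsewhere and stayed within the scatter. A modest step toward a higher number is expected, a 1.5-fold higher number from compound 3 to compound 4 (0.17 log units; within the scatter), in this assay. Compound 4 is estimated at 1400 nM in this assay, with a range from 450 nM to 4500 nM.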

Compound 4, half-maximal inhibitory concentration: 2160 nM
For compound 4 the middle estimate is 1.5-fold (0.19 log units) below the measured one; measured number inside the range.
By their numbers in this assay, from the lowest: compound 3; then compounds 4, 2 and 1 (each within the scatter of the next).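

On this aromatic carbon, para to a large group and meta to a (vinylcarbonyl)amino group, putting methylsulfonyl in place of methylsulfanyl gives a 2.3-fold higher number from compound 3 to compound 4 (0.36 log units; beyond the scatter) in this assay. The earlier exchange on a chain elsewhere gave only a 1.1-fold lower number from compound 1 to compound 2 (0.03 log units; within the scatter), so this is the one step shown that lies beyond the scatter, and it shows that a change at this position can move the number. No measurement shown explains why the number moves with this exchange.

On these data alone, it remains open how an amine or a carboxylic acid on this same aromatic carbon would compare with methylsulfanyl and methylsulfonyl. Compounds 1 and 2 differ from compounds 3 and 4 in more than one place, so the size of this step cannot be carried over to them.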